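This account rests on a few compounds, and the source may have more. Where it says the series, first, only, none or still open, it means among the compounds named here.

Measured so far:
compound 1, `O=C(CCCCNC(=O)Cn1cnc2c(Nc3ccccc3)nc(Nc3ccccc3)nc21)NO`, 11100 nM
compound 2, `O=C(CCCCCNC(=O)Cn1cnc2c(Nc3ccccc3)nc(Nc3ccccc3)nc21)NO`, 1610 nM

Both compounds were tested in a functional assay on MDA-MB-231 cells (Homo sapiens) for inhibition, read by MTT assay, with a stated time of 48 h; on this read-out higher numbers stand for weaker inhibition and lower numbers for stronger inhibition. They share a core bearing two anilino groups, from which a chain runs out to a hydroxamic acid end group. Among the compounds with values here, compound 1 stands at the highest of the two numbers; its only neighbour, compound 2, lies lower by a 6.9-fold lower number from compound 1 to compound 2 (0.84 log units; beyond the scatter), a change that sits in the chain, where (hydroxycarbamoyl)methyl takes the place of hydroxycarbamoyl on a saturated chain carbon.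

Compound 3, `O=C(CCCCNC(=O)Cn1cnc2c(Nc3ccccc3)ncnc21)NO`, keeps the chain of compound 1 and instead alters the core: hydrogen in place of anilino on an aromatic carbon. One anilino group leaves from an aromatic carbon that sits between two ring nitrogen atoms, and a hydrogen enters there. Within the data shown here, the single measured step concerns the chain only, so no measured step bears on this change, and the data give no guide to its direction. Losing a whole anilino group is a larger alteration than the chain step, so a move toward weaker inhibition is expected for compound 3, on the order of a 2.0-fold higher number from compound 1 to compound 3 (0.30 log units; within the scatter). Compound 3 is therefore estimated at 22000 nM, within a range from 5000 nM to 90000 nM.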

Compound 3, half-maximal inhibitory concentration: > 50000 nM
Compound 3: no number, only a limit; the forecaster's own chance of this, stated with the estimate: 20%; middle value at least 2.2-fold (0.35 log units) away from the limit.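

Taking the anilino group off the aromatic carbon between two ring nitrogen atoms and leaving a hydrogen there is the first change to the shared core, and in this assay it gives an at least 4.5-fold higher number from compound 1 to compound 3 (0.65 log units; beyond the scatter). The earlier step touched only the chain, so this result adds something new: inhibition in these cells also depends on what sits at this place on the core, and with a hydrogen there it is clearly weaker than with the anilino group of compound 1. The reading for compound 3 is a limit of the assay and not a number, so the step gives only the smallest size the loss can have, and its true size stays unknown: the limit of > 50000 nM in this assay, at which 1 of the 3 values shown sits.

The compounds shown leave open whether a ring is needed at this carbon at all, or whether a smaller group such as an amine or a methyl group would keep part of the inhibition. They also leave open whether the longer chain of compound 2 would recover any inhibition in a compound that has a hydrogen at this place.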